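Hydroxy added to compound 2: expected inhibition of compound 3

The compounds below may be only part of what the source reports. "The series", "measured", "known", "first", "only" and "open" are said of these compounds alone.

Of the compounds shown here, two have been measured. Compound 1 `O=C(/C=C(O)/C=C/c1ccc(O)c(O)c1)c1ccccc1O` gives 93.6% in an assay on isolated protein for inhibition of Alpha glucosidase (Homo sapiens), with stated times of 5 min and 15 min, tested at 50 uM (on this read-out lower numbers stand for less inhibition and higher numbers for more inhibition at the one concentration tested (going by the name of the read-out)), and compound 2 `O=C(/C=C(O)/C=C/c1cccc(O)c1)c1cc(Cl)ccc1O` gives 62.4% in this assay; compound 2 thus stands lowest of the two numbers, and its gap to compound 1 lies beyond the usual scatter. Among the compounds with values here, no pair of measured compounds differs in only one place, so no single structural step has yet been quantified.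

Compound 3 `O=C(/C=C(O)/C=C/c1ccc(O)c(O)c1)c1cc(Cl)ccc1O` remains to be measured in this assay. Relative to compound 2 the change is hydroxy in place of hydrogen on an aromatic carbon. Given the higher reading of compound 1 at 93.6%, the step from compound 2 to compound 3 is expected to be upward and beyond the scatter, estimated as a number 21.6 percentage points higher from compound 2 to compound 3 (beyond the scatter). For compound 3 the estimated value in this assay is 84%, with an expected range from 65% to 97%.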

Compound 3, a percentage reported as inhibition, at one concentration (the size of the read-out at that concentration, not a potency): 85.6%
Beside the measured number, compound 3's estimate is 1.6 percentage points below it; the measured number falls inside the stated range.
By their numbers in this assay, from the lowest: compound 2; then compounds 3 and 1 (each within the scatter of the next).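

In this assay, within the data shown here, the first single-place reading at this position is a number 23.2 percentage points higher from compound 2 to compound 3 (beyond the scatter) for hydroxy in place of hydrogen on an aromatic carbon, ortho to a hydroxy group and para to a large group, so this position matters in the chloro-bearing pair. The second reading is a number 8 percentage points lower from compound 1 to compound 3 (within the scatter) for a chloro group that compound 3 carries and compound 1 lacks, so with this hydroxy present the read-out does not separate the chloro compound from its hydrogen counterpart. No measured information bears on the reason for either step.

The compounds shown leave open whether the hydroxy step holds without the chloro group, and whether a methoxy group or an amine at this position would give a similar reading. A reading at one concentration also leaves any potency difference between compound 1 and compound 3 undefined.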